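This account rests on a few compounds, and the source may have more. Where it says the series, first, only, none or still open, it means among the compounds named here.

Working notes on the aryloxy series, step from compound 3 to compound 4.

Among the measured compounds shown here, in a functional assay on HEK293 cells for agonist activity at Free fatty acid receptor 1 (Homo sapiens), read by calcium flux (on this read-out higher numbers stand for an effect only at larger amounts of compound and lower numbers for an effect already at smaller amounts), compound 3 `C=C(C)CCOc1ccc(C(CC(=O)O)c2ccccc2)cc1` gives 2.71 uM, the second highest of the three numbers so far. Compound 2 `CCCCCCOc1ccc(C(CC(=O)O)c2ccccc2)cc1` gives 2.88 uM, within the scatter of compound 3, whereas compound 1 `CCCCOc1ccc(C(CC(=O)O)c2ccccc2)cc1` gives 1.2 uM, the difference a 2.3-fold higher number from compound 1 to compound 3 (0.35 log units; beyond the scatter) being beyond the scatter.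

Compound 4 `CCC(CC)COc1ccc(C(CC(=O)O)c2ccccc2)cc1` carries pentan-3-yl in place of 2-methylprop-2-en-1-yl on a saturated chain carbon bound to an oxygen on an aromatic ring. Bearing on this: chain extension, a 2.4-fold higher number from compound 1 to compound 2 (0.38 log units; beyond the scatter); the branched unsaturated chain, a 2.3-fold higher number from compound 1 to compound 3 (0.35 log units; beyond the scatter); and between the two larger chains, a 1.1-fold lower number from compound 2 to compound 3 (0.03 log units; within the scatter). The larger saturated branched chain of compound 4 most resembles compound 2, so in this assay the step of a 1.3-fold higher number from compound 3 to compound 4 (0.11 log units; within the scatter) is expected to stay small, at most a slight rise. Compound 4 is estimated at 3.5 uM, range 1.5 uM to 8 uM.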

Compound 4, concentration for half-maximal effect: 0.64 uM
Compound 4: middle estimate off by 5.5-fold (0.74 log units), on the high side; measured number below the stated range.
By their numbers in this assay, from the lowest: compounds 4 and 1 (each within the scatter of the next); then compounds 3 and 2 (each within the scatter of the next).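

Branching decides the outcome at this saturated chain carbon bound to an oxygen on an aromatic ring: pentan-3-yl in place of pentyl gives (a 4.5-fold lower number from compound 2 to compound 4 (0.65 log units; beyond the scatter)), and in place of 2-methylprop-2-en-1-yl it gives (a 4.2-fold lower number from compound 3 to compound 4 (0.63 log units; beyond the scatter)), so in this assay a larger chain need not raise the number, as compounds 2 and 3 alone suggested. The shorter chain of compound 1 remains level with this branched chain (a 1.9-fold lower number from compound 1 to compound 4 (0.27 log units; within the scatter)). Nothing measured here accounts for the branching result.

Still open, from the compounds shown here alone, is how a cyclopentyl group or a longer branched chain would behave at this place.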